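Swapping a phenyl ring for a thiophene in compound 1

The source may report more compounds than this note shows. Statements on the series, on what has been measured and on what is new or still open speak of the compounds shown alone.

Values in a functional assay on MGC-803 cells (Homo sapiens) for antiproliferative activity, read by MTT assay, with a stated time of 72 h; a higher number here means a weaker inhibitor, a lower number a stronger inhibitor:
Compound 1 `Cc1ccc(-c2nc(CNc3ccc(C(=O)NO)cc3)n(-c3ccccc3)n2)cc1`: > 20000 nM (a limit)
Compound 2 `COc1ccc(-n2nc(-c3ccccc3)nc2CNc2ccc(C(=O)NO)cc2)cc1`: 7050 nM
Compound 3 `O=C(NO)c1ccc(NCc2nc(-c3ccccc3)nn2-c2ccc(F)cc2)cc1`: 10500 nM

Compound 1 gives no actual number, only (the limit of > 20000 nM in this assay, at which 1 of the 3 values shown sits). It is a limit of the assay, so the starting point of this step is known only on one side.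

Compound 4 `Cc1ccc(-c2nc(CNc3ccc(C(=O)NO)cc3)n(-c3ccccc3)n2)s1` keeps the core of compound 1 and changes one group, with 5-methylthiophen-2-yl in place of 4-methylphenyl on an aromatic carbon of the five-membered aromatic ring with 3 nitrogen. The counted difference is 5-methylthiophen-2-yl in place of 4-methylphenyl on an aromatic carbon.

Among the compounds with values here, no measured step tests this swap. Within the data shown here, the only step available is a 1.5-fold higher number from compound 2 to compound 3 (0.17 log units; within the scatter), a change of fluoro for methoxy, which is a different replacement from the one here. It offers only a weak hint that a single substituent change in this series can leave this assay little altered. Compound 2 at 7050 nM and compound 3 at 10500 nM also show what measurable values look like in this series.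

No step beyond the scatter is therefore expected, and the estimated step is an at least 1.3-fold lower number from compound 1 to compound 4 (0.12 log units; that floor lies within the scatter). For compound 4 the expected value is 15000 nM, with an estimated range of 6000 nM to 30000 nM.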

Compound 4, half-maximal inhibitory concentration: 8450 nM
Estimate against measurement, compound 4: 1.8-fold (0.25 log units) above; the measured number falls inside the stated range.
By their numbers in this assay, from the lowest: compounds 2, 4 and 3 (each within the scatter of the next). At a limit, above all of these: compound 1.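

In this assay, the position on the five-membered aromatic ring with 3 nitrogen that carries the 4-methylphenyl group responds to a single change: putting 5-methylthiophen-2-yl in its place gives an at least 2.3-fold lower number from compound 1 to compound 4 (0.37 log units; beyond the scatter). The only earlier step, fluoro in place of methoxy, sits at a different place in the molecule and stays within the scatter, so this is the first sign among the compounds shown that one change can move the number by more than repeat measurements would. Compound 1 gives only a limit of the assay and not a number, so the size of this step is known on one side only, as a floor and not as a measured gap: the limit of > 20000 nM in this assay, at which 1 of the 4 values shown sits.

The compounds shown do not separate the effect of the thiophene ring from that of the methyl group it carries, and a plain thiophen-2-yl group would help to pull the two apart. On these data alone, how a furan ring, a pyridine ring or a phenyl ring bearing an amine or a carboxylic acid would fare at this position also remains open.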